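The source may hold more compounds than are shown below. What is called first, only, known or untested is meant among the compounds shown, and "the series" means these compounds.

Compound 1, `CCCOc1cc(=O)oc2cc(OCc3ccccc3)ccc12`: 575 nM
Compound 2, `CCOc1cc(=O)oc2cc(OCc3cccc(Br)c3)ccc12`: 126 nM
Compound 3, `CC(=O)COc1cc(=O)oc2cc(OCc3cccc(Cl)c3)ccc12`: 26.9 nM

Of the compounds shown here, three have been measured in an assay on isolated protein (strain Sprague-Dawley) for inhibition of Amine oxidase [flavin-containing] B (Rattus norvegicus), read by spectrophotometry, with a stated time of 5 min; a higher number here means a weaker inhibitor, a lower number a stronger inhibitor. Compound 3 gives the lowest number of the three. Its nearest neighbour is compound 2, whose number is higher by an amount beyond the usual scatter, and compound 1 lies further still, also beyond the scatter. On the numbers shown, compound 3 is therefore the strongest inhibitor of the set.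

The next compound, compound 4, `O=c1cc(CO)c2ccc(OCc3cccc(Cl)c3)cc2o1`, has not yet been measured in this assay. It differs from compound 3 in one place: hydroxymethyl in place of 2-oxopropoxy on an aromatic carbon. Among the measured compounds shown here, the three measured compounds all carry an alkoxy-type chain at this position, so no measured pair shows what a shorter hydroxymethyl group does here. For the measured compounds named here, the account can only weigh that the lowest number so far belongs to a compound with the larger chain, and that shortening to the two-heavy-atom hydroxymethyl is a substantial change.

Compound 4 is expected to give a weaker result, with the step of a 5.6-fold higher number from compound 3 to compound 4 (0.75 log units; beyond the scatter) estimated to lie beyond the scatter. The estimate for compound 4 in this assay is 150 nM, with a range from 40 nM to 600 nM.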

Compound 4, half-maximal inhibitory concentration: 5.25 nM
Compound 4: the middle estimate sits 29-fold (1.46 log units) above what was measured; the measured number lies below the stated range.
By their numbers in this assay, from the lowest: compound 4; then compound 3; then compound 2; then compound 1.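

Putting hydroxymethyl in place of 2-oxopropoxy on this aromatic carbon, opposite the ring oxygen, gives a 5.1-fold lower number from compound 3 to compound 4 (0.71 log units; beyond the scatter) in this assay, so a low number at this position does not depend on the larger chain: the group of 2 heavy atoms does better than the group of 5. The change also replaces a chain with 0 hydrogen-bond donors and 2 acceptors by a group with 1 of each and removes the double bond outside the aromatic rings, so this single pair cannot show which of these differences matters. Nothing available here explains the lower number.

From the compounds shown here alone, it remains open whether a methyl, a methoxymethyl, an aminomethyl or a carboxylic acid at this position would match hydroxymethyl, and whether the hydrogen-bond donor of that group has any part in the result. Going by these compounds, it is also open whether the same exchange would lower the number to a similar extent in compounds carrying the bromine-substituted or unsubstituted benzyl group of compound 2 and compound 1.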